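Replacing 2-phenylethenyl with 2-chlorophenyl in the series

The source may hold more compounds than are shown below. What is called first, only, known or untested is meant among the compounds shown, and "the series" means these compounds.

Of the compounds shown here, two have numbers so far in a functional assay on K562 cells (Homo sapiens) for antiproliferative activity, with a stated time of 72 h; on this read-out lower numbers stand for stronger inhibition and higher numbers for weaker inhibition. Compound 1 `COc1ccc(-c2cc([C@@H]3O[C@H](CO)[C@@H](O)[C@H]3O)n3ncnc(N)c23)cc1` gives 76400 nM. Compound 2 `Nc1ncnn2c([C@@H]3O[C@H](CO)[C@@H](O)[C@H]3O)cc(/C=C/c3ccccc3)c12` gives 3100 nM, the lower of the two numbers. Next is compound 3 `Nc1ncnn2c([C@@H]3O[C@H](CO)[C@@H](O)[C@H]3O)cc(-c3ccccc3Cl)c12`, with this change from compound 2: 2-chlorophenyl in place of 2-phenylethenyl on an aromatic carbon. In short, 2-chlorophenyl stands in place of 2-phenylethenyl on an aromatic carbon. Among the compounds with values here, one measured step bears on this: a 25-fold lower number from compound 1 to compound 2 (1.39 log units; beyond the scatter), a large step beyond the scatter, with 2-phenylethenyl in place of 4-methoxyphenyl at the same carbon. Compound 3 gives up 2-phenylethenyl and again carries a substituted phenyl group there, like compound 1 at 76400 nM. A higher number in this assay is therefore expected, though the effect of 2-chlorophenyl itself is unmeasured. The expected change is a 6.5-fold higher number from compound 2 to compound 3 (0.81 log units; beyond the scatter). For compound 3 the estimated value is 20000 nM, with an expected range of 4000 nM to 90000 nM.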

Compound 3, half-maximal inhibitory concentration: > 100000 nM
Compound 3: a limit, no number; the forecaster's own chance of this, stated with the estimate: 15%; middle value at least 5.0-fold (0.69 log units) away from the limit.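

In this assay compound 3 gives a limit of the assay, not a number: the limit of > 100000 nM in this assay, at which 1 of the 3 values shown sits. Even so, the step can be read as a floor, an at least 32-fold higher number from compound 2 to compound 3 (1.50 log units; beyond the scatter), so at this aromatic carbon 2-phenylethenyl now stands apart from two different substituted phenyl groups, not just from 4-methoxyphenyl. The second floor, an at least 1.3-fold higher number from compound 1 to compound 3 (0.11 log units; that floor lies within the scatter), sets no order between 2-chlorophenyl and 4-methoxyphenyl, so the series gives no read on how the phenyl substituent matters here.

Still open, going by these compounds, is whether the gain with 2-phenylethenyl needs its double bond, which a saturated 2-phenylethyl chain or a 2-phenylethynyl group at the same carbon would test. Also open, on these data alone, is whether an unsubstituted phenyl group or a small amine there would give a number clear of the limit.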